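This account rests on a few compounds, and the source may have more. Where it says the series, first, only, none or still open, it means among the compounds named here.

Measured compounds in an assay on CHO cells for agonist activity at Neuronal acetylcholine receptor; alpha3/alpha6/beta2/beta3 (Homo sapiens), read by FLIPR and calcium flux; on this read-out higher numbers stand for an effect only at larger amounts of compound and lower numbers for an effect already at smaller amounts:
- compound 1, `O=C(C1CCC1)N1CC2CC(C1)N2`: compound 1 gives 370 nM
- compound 2, `C[C@@H]1C[C@@H]1C(=O)N1CC2CC(C1)N2`: compound 2 gives 920 nM
- compound 3, `C[C@H]1C[C@H]1C(=O)N1CC2CC(C1)N2`: compound 3 gives 2000 nM

Compound 3 stands at the highest number of the three. Against compound 1 the step is a 5.4-fold higher number from compound 1 to compound 3 (0.73 log units; beyond the scatter), the exchange of cyclobutyl for 2-methylcyclopropyl on the carbonyl carbon. Against compound 2 the step is a 2.2-fold higher number from compound 2 to compound 3 (0.34 log units; beyond the scatter), and here the two compounds share every atom and bond and differ only in the configuration drawn at two stereocentres of the three-membered ring; the one point of evidence on this pair is the fact that one of compounds 2 and 3 is drawn with a defined configuration and the other without, at the place where they differ.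

Compound 4, `C[C@@H]1C[C@H]1C(=O)N1CC2CC(C1)N2`, is next. the two compounds have the same atoms and bonds; at least one stereo element is drawn with a configuration in one of them and without one in the other: 1 of 4 stereo elements differ; a stereocentre at a saturated ring carbon is drawn S in compound 3 and R in compound 4 In words: the same atoms and bonds as compound 3, with the configuration at one saturated ring carbon turned from S to R, so that compound 4 is a third stereoisomer of the same 2-methylcyclopropyl amide, related to both compound 2 and compound 3 by one ring stereocentre. Going by the values given here, the only measured step that bears on it is the purely stereochemical one, a 2.2-fold higher number from compound 2 to compound 3 (0.34 log units; beyond the scatter), which was modest; the two steps from compound 1 show that the 2-methylcyclopropyl amides as a group sit at higher numbers than the cyclobutyl amide. On these data alone, a stereochemical change of this kind is therefore expected to move the number by a modest amount at most, in either direction, and with no measured diastereomer of this type the direction stays open. Compound 4 is expected to land near 1200 nM, between 400 nM and 3500 nM. The step from compound 3 this estimate implies is a 1.7-fold lower number from compound 3 to compound 4 (0.22 log units; within the scatter).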

Compound 4, half-maximal effective concentration: 51 nM
Compound 4: the middle estimate sits 24-fold (1.37 log units) above what was measured; measured number below the stated range.
By their numbers in this assay, from the lowest: compound 4; then compound 1; then compound 2; then compound 3.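

In this assay, the configuration of the 2-methylcyclopropyl ring matters far more than the first stereochemical pair suggested: the change at one saturated ring carbon gives a 39-fold lower number from compound 3 to compound 4 (1.59 log units; beyond the scatter), and the other pair sharing a one-centre difference gives an 18-fold lower number from compound 2 to compound 4 (1.26 log units; beyond the scatter), both well beyond the earlier 2.2-fold higher number from compound 2 to compound 3 (0.34 log units; beyond the scatter). The 2-methylcyclopropyl amides also no longer sit as a group at higher numbers than the cyclobutyl amide, since the exchange on the carbonyl carbon now gives a 7.3-fold lower number from compound 1 to compound 4 (0.86 log units; beyond the scatter), while compound 2 and compound 3 go the other way. The record on the sharpest of these pairs reaches only to the drawing of the stereocentres: the fact that one of compounds 3 and 4 is drawn with a defined configuration and the other without, at the place where they differ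

On these data alone, whether an ethyl or methoxy group in place of the methyl, in the configuration of compound 4, would hold the low number stays open. So does the standing of the unsubstituted cyclopropyl amide against compound 4.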